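The compounds below may be only part of what the source reports. "The series", "measured", "known", "first", "only" and "open" are said of these compounds alone.

Compound 1 `COc1cc2c(cc1O)CCC(C(=O)NCc1ccccc1)O2` and compound 2 `CCCNC(=O)C1CCc2cc(O)c(OC)cc2O1` share one core; compound 3 `COc1cc2c(cc1O)C(=O)CC(C(=O)NCc1ccccc1)O2` and compound 4 `CCCNC(=O)C1CC(=O)c2cc(O)c(OC)cc2O1` share another. The difference between the two cores is not broken down here. In a functional assay (brain) for inhibition, with Rattus norvegicus as the target (a lower number here means a stronger inhibitor, a higher number a weaker inhibitor), compound 1 gives 16600 nM. In this assay compound 2 gives 119000 nM. The change ethyl in place of phenyl on a saturated chain carbon bound to an amide-type nitrogen thus gave a 7.2-fold higher number from compound 1 to compound 2 (0.86 log units; beyond the scatter). For compound 3 the assay reports only a limit, > 300000 nM (the limit of > 300000 nM in this assay, at which 1 of the 3 values shown sits). Compound 4 differs from compound 3 by ethyl in place of phenyl on a saturated chain carbon bound to an amide-type nitrogen, the same change at the same place. For the measured compounds named here, the step of a 7.2-fold higher number from compound 1 to compound 2 (0.86 log units; beyond the scatter) is the only reference for compound 4. Compound 4 is expected to remain beyond the limit, with a step that the limit leaves unreadable from compound 3 to compound 4 expected to resemble that earlier step. Compound 4 is estimated at 2000000 nM, between 400000 nM and 10000000 nM, and will most likely be returned only as a limit.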

Compound 4, half-maximal inhibitory concentration: > 300000 nM
Compound 4: no number, only a limit (the forecaster's own chance of this, stated with the estimate: 90%); the middle value lies beyond the limit too.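

For the compounds shown here, compound 3 and compound 4 both return only a limit, so no step between them can be read: the limit of > 300000 nM in this assay, at which 2 of the 4 values shown sit. The compounds shown leave open whether ethyl in place of phenyl shifts the number on the core of compound 3 at all.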